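Notes on replacing 4-cyanophenyl in compound 2

The source may hold more compounds than are shown below. What is called first, only, known or untested is meant among the compounds shown, and "the series" means these compounds.

Of the compounds shown here, two sharing one core have numbers so far in a functional assay on QGY-7703 cells (Homo sapiens) for cytotoxicity, read by MTT assay, with a stated time of 24 h; on this read-out higher numbers stand for weaker inhibition and lower numbers for stronger inhibition. Compound 1 (`CC(=O)Nc1ccc(S(=O)(=O)N2C/C(=C\c3ccccc3F)C(=O)/C(=C/c3ccccc3F)C2)cc1`) gives 5500 nM, and compound 2 (`CC(=O)Nc1ccc(S(=O)(=O)N2C/C(=C\c3ccc(C#N)cc3)C(=O)/C(=C/c3ccccc3F)C2)cc1`) gives 2050 nM, the lower of the two numbers. Compound 3 (`COc1cc(/C=C2\CN(S(=O)(=O)c3ccc(NC(C)=O)cc3)C/C(=C\c3ccccc3F)C2=O)cc(OC)c1`) has not yet been measured and differs from compound 2 in one group: 3,5-dimethoxyphenyl in place of 4-cyanophenyl on a double-bonded chain carbon bound to a double-bonded ring carbon. Among the measured compounds shown here, the only measured step bearing on this place is a 2.7-fold lower number from compound 1 to compound 2 (0.43 log units; beyond the scatter), with 4-cyanophenyl in place of 2-fluorophenyl. That step is modest but beyond the scatter, so the group at this place can shift the number in this assay. For the measured compounds named here, no measured compound carries 3,5-dimethoxyphenyl, so the data give no direct read on it. Going by the values given here, with a single step as the guide, a change no larger than that step is expected, and a slightly higher number is more likely than a lower one, as compound 2 at 2050 nM holds the lowest number so far. The expected change is a 1.5-fold higher number from compound 2 to compound 3 (0.17 log units; within the scatter). For compound 3 the estimated value is 3000 nM, with an expected range of 1200 nM to 7000 nM.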

Compound 3, half-maximal inhibitory concentration: 3690 nM
Compound 3: the middle estimate sits 1.2-fold (0.09 log units) below what was measured; measured number inside the range.
By their numbers in this assay, from the lowest: compounds 2, 3 and 1 (each within the scatter of the next, the first and the last beyond it).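

In this assay, the place on a double-bonded chain carbon bound to a double-bonded ring carbon now accepts 3,5-dimethoxyphenyl, with its two oxygens and 10 heavy atoms, without a separation from either earlier compound: the change from 4-cyanophenyl gives a 1.8-fold higher number from compound 2 to compound 3 (0.26 log units; within the scatter) and the change from 2-fluorophenyl gives a 1.5-fold lower number from compound 1 to compound 3 (0.17 log units; within the scatter) at this place. The new compound therefore does not add a second step beyond the scatter, and the only such gap among the three remains a 2.7-fold lower number from compound 1 to compound 2 (0.43 log units; beyond the scatter) so that compound 3 can be placed apart from neither end of that gap, and the series shows no ranking of all three groups. Nothing available explains the size of these steps or links them to any feature of the groups.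

The compounds shown leave open what an amine, a carboxylic acid or a longer chain would give at this place, since all three groups here are substituted phenyl rings. They also leave open whether the same small steps would appear with a morpholine or a pyridine ring in place of the remaining 2-fluorophenyl on the shared core.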